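This account rests on a few compounds, and the source may have more. Where it says the series, first, only, none or still open, it means among the compounds named here.

Working notes on the series. Among the compounds with values here, in a functional assay on Bel-7402 cells (Homo sapiens) for cytotoxicity, read by MTT assay, with a stated time of 72 h (on this read-out lower numbers stand for stronger inhibition and higher numbers for weaker inhibition), compound 1 `C=C1C(=O)[C@@]23C(=O)OC[C@]4(C(=O)CCC(C)(C)[C@H]4C=O)[C@@H]2CC[C@@H]1[C@H]3OC(C)=O` gives 1730 nM and compound 2 `C=C1C(=O)[C@@]23C(=O)OC[C@]4(C(=O)CCC(C)(C)[C@H]4C=O)[C@@H]2CC[C@@H]1[C@H]3OC(=O)c1ccc(OC)cc1` gives 2800 nM, which places compound 2 within the scatter of the only other number. Compound 3 `C=C1C(=O)[C@@]23C(=O)OC[C@]4(C(=O)CCC(C)(C)[C@H]4C=O)[C@@H]2CC[C@@H]1[C@H]3OC(=O)c1ccc(C(F)(F)F)cc1` follows from compound 2 with trifluoromethyl in place of methoxy on an aromatic carbon, on an aromatic carbon, para to a large group. Within the data shown here, one measured step bears on this: a 1.6-fold higher number from compound 1 to compound 2 (0.21 log units; within the scatter), a larger exchange at the same carbonyl carbon. On that evidence no change beyond the scatter is expected in this assay. The expected step is a 1.2-fold lower number from compound 2 to compound 3 (0.09 log units; within the scatter). For compound 3 the estimated value is 2300 nM, with an expected range of 1000 nM to 5500 nM.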

Compound 3, half-maximal inhibitory concentration: 3990 nM
Compound 3: middle estimate off by 1.7-fold (0.24 log units), on the low side; the measured number falls inside the stated range.
By their numbers in this assay, from the lowest: compounds 1, 2 and 3 (each within the scatter of the next, the first and the last beyond it).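

In this assay the exchange on the aromatic carbon gives a 1.4-fold higher number from compound 2 to compound 3 (0.15 log units; within the scatter) and so does not separate methoxy from trifluoromethyl at this place. Within the data shown here, the exchange at the carbonyl carbon gives a 2.3-fold higher number from compound 1 to compound 3 (0.36 log units; beyond the scatter) and is the first step to pass the scatter, a modest one. Compound 2, with 4-methoxyphenyl on that carbonyl carbon, stays within the scatter of compound 1, so this separation holds for the 4-(trifluoromethyl)phenyl group alone.

Going by these compounds, whether an amine or a carboxylic acid on this aromatic carbon, or a longer chain in place of the methyl on the carbonyl carbon, would shift the number further stays open. Nothing at hand accounts for these numbers.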